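A Chloro-to-Methyl Swap Among Weak Growth Inhibitors

This account rests on a few compounds, and the source may have more. Where it says the series, first, only, none or still open, it means among the compounds named here.

In a functional assay on A-375 cells (Homo sapiens) for inhibition, read by CCK-8 assay, with a stated time of 72 h, tested at 2 uM (a higher number here means more inhibition of growth at the concentration tested, a lower number less inhibition of growth), compound 1 `Nc1ccccc1NC(=O)/C=C/c1ccc(CSc2ccc(Cl)cc2)cc1` gives 13.4% and lies within the scatter of both other measured compounds. Compound 2 `COc1ccc(SCc2ccc(C(=O)Nc3ccccc3N)cc2)cc1` gives 10.2% and compound 3 `CCc1ccc(SCc2ccc(C(=O)Nc3ccccc3N)cc2)cc1` gives 19.6% in the same test, so the three cannot be ranked. Compound 4 `Cc1ccc(SCc2ccc(/C=C/C(=O)Nc3ccccc3N)cc2)cc1` keeps the core of compound 1. The change is methyl in place of chloro on an aromatic carbon and amounts to methyl in place of chloro on an aromatic carbon, para to a large group. Within the data shown here, no measured step makes this swap. Among the measured compounds shown here, the only measured step is a number 9.4 percentage points higher from compound 2 to compound 3 (within the scatter) and it involves other groups on another core, so it offers weak guidance. No shift beyond the scatter is expected, and the estimated change is a number 1.6 percentage points higher from compound 1 to compound 4 (within the scatter) in this assay overall. Compound 4 is expected to give 15% with an estimated range of 4% to 28% in this test.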

Compound 4, percent growth inhibition at one concentration: 22.9%
Compound 4: the middle estimate sits 7.9 percentage points below what was measured; measured number inside the range.
By their numbers in this assay, from the lowest: compounds 2, 1, 3 and 4 (each within the scatter of the next, the first and the last beyond it).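

The swap of methyl for chloro, on an aromatic carbon para to a large group, gives a number 9.5 percentage points higher from compound 1 to compound 4 (within the scatter) in this assay. Among these compounds, this is the first direct reading of this change at this position, and on the core of compound 1 the two groups cannot be told apart in this test. Nothing at hand explains the result or links it to either group.

On these data alone, it remains open whether an amine, a carboxylic acid or a longer chain at this position would move the number beyond the scatter. As far as these compounds go, it is also open whether the same swap would read alike on the core of compound 2.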